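A few compounds are considered here, and "the series" means these few. Any claim that something is new, unique, unknown or untested is made for them only; others in the source may bear on it.

Values so far in a functional assay on ileum (Cavia porcellus) for antagonist activity (on this read-out higher numbers stand for weaker inhibition and lower numbers for stronger inhibition), for the shared core:

- compound 1 `CCCc1c(OCCCOc2ccc3c(O)c([N+](=O)[O-])c(=O)oc3c2)ccc(C(C)=O)c1O` gives 100 nM
- compound 2 `CC(=O)c1ccc(OCC(O)COc2ccc3c(O)c([N+](=O)[O-])c(=O)oc3c2)c(C)c1O` gives 500 nM
- compound 3 `CCCc1c(OCC(O)COc2ccc3c(O)c([N+](=O)[O-])c(=O)oc3c2)ccc(C(C)=O)c1O` gives 80 nM

Compound 3 at 80 nM shares the low end of these numbers with compound 1 and stands clearly under compound 2 only. Compound 4 `CCCc1c(OCC(O)COc2ccc3c(O)c([N+](=O)[O-])c(=O)oc3c2CCC)ccc(C(C)=O)c1O` is compound 3 with one change propyl in place of hydrogen on an aromatic carbon that is propyl in place of hydrogen on an aromatic carbon. Within the data shown here, no measured step touches that place on the core. The step of a 1.3-fold lower number from compound 1 to compound 3 (0.10 log units; within the scatter) came with hydroxy in place of hydrogen on the chain and says little here. The closest guide is the step of a 6.3-fold lower number from compound 2 to compound 3 (0.80 log units; beyond the scatter) with ethyl in place of hydrogen on a saturated chain carbon bound to an aromatic carbon. It is the only measured case of added carbon chain, and it lies elsewhere in the molecule. It points to a modest fall in this assay but cannot secure the direction. The expected step is a 2.3-fold lower number from compound 3 to compound 4 (0.36 log units; beyond the scatter) as an estimate from this single comparison. Compound 4 is expected near 35 nM with an estimated range from 10 nM to 120 nM for its measurement.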

Compound 4, half-maximal inhibitory concentration: 200 nM
The estimate for compound 4 lay 5.7-fold (0.76 log units) below the measured number; the measured number lies above the stated range.
By their numbers in this assay, from the lowest: compounds 3, 1 and 4 (each within the scatter of the next, the first and the last beyond it); then compound 2.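

In this assay, among these compounds, propyl in place of hydrogen on this aromatic carbon gives a 2.5-fold higher number from compound 3 to compound 4 (0.40 log units; beyond the scatter) and so weaker inhibition, a modest loss at a place on the shared core that no earlier pair had tested. Added carbon chain therefore does not act the same way everywhere: ethyl in place of hydrogen on a saturated chain carbon gave a 6.3-fold lower number from compound 2 to compound 3 (0.80 log units; beyond the scatter) and went the other way, so compound 4 stands against any rule that more chain lowers the number. Nothing available explains why the two changes differ.

From the compounds shown here alone, whether methyl, a longer chain such as butyl, or an amine on this same aromatic carbon would give a lower or a higher number stays open. With propyl as the only group shown here, one step cannot describe the trend at this place.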